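The source may hold more compounds than are shown below. What is called first, only, known or untested is meant among the compounds shown, and "the series" means these compounds.

Three compounds share one core and were tested in a functional assay, tested at 100 ug/mL; a lower number here means a stronger effect, a higher number a weaker effect of the compound at the concentration tested. Compound 1 `CCOC(=O)C1=C(C)N(c2ccc(F)cc2)C=CC1c1ccccc1` gives -25.7% in this assay. Compound 2 `CCOC(=O)C1=C(C)N(c2ccc(Cl)cc2)C=CC1c1ccccc1` gives -19.1% in this assay, and compound 3 `COC(=O)C1=C(C)N(c2ccc(OC)cc2)C=C(C)C1c1ccccc1` gives -19.8% in this assay. Among the three numbers, compound 3 stands second, with compound 2 nearest and compound 1 furthest, and both gaps lie within the scatter. Within the data shown here, the only step between measured compounds that differ in one place is a number 6.6 percentage points higher from compound 1 to compound 2 (within the scatter).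

Compound 4 `COC(=O)C1=C(C)N(c2cccc(Cl)c2)C=C(C)C1c1ccccc1` has not yet been measured. It differs from compound 3 by 3-chlorophenyl in place of 4-methoxyphenyl on an amine nitrogen in a ring. Among the measured compounds shown here, the single measured step concerns chloro in place of fluoro on an aromatic carbon, not a 4-methoxyphenyl giving way to a 3-chlorophenyl on an amine nitrogen in a ring, so it bears on this change only loosely, and it was within the scatter. For the measured compounds named here, no measured pair sets methoxy against chloro. One therefore expects a step of a number 0.2 percentage points lower from compound 3 to compound 4 (within the scatter), nothing beyond the scatter. In this assay compound 4 is estimated at -20%, expected to fall between -36% and -4%.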

Compound 4, a percentage reported as activity, at one concentration (the size of the read-out at that concentration, not a potency): -21.3%
Estimate against measurement, compound 4: 1.3 percentage points above; low and high end bracket the measured number.
By their numbers in this assay, from the lowest: compounds 1, 4, 3 and 2 (each within the scatter of the next).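

In this assay, replacing 4-methoxyphenyl with 3-chlorophenyl on an amine nitrogen in a ring gives a number 1.5 percentage points lower from compound 3 to compound 4 (within the scatter). Among these compounds, the only earlier step at this nitrogen exchanged one halogen for another on the aromatic ring, whereas this one changes both the group on that ring and its place, and the read-out still shows no change beyond the scatter. Nothing available explains this result.

Since the group and its place changed together in one step, the compounds shown cannot separate the effect of either alone, and they do not show whether 3-methoxyphenyl or 4-chlorophenyl would behave the same way on this core. They also leave open whether a carboxylic acid or an amine on that ring, or a cyclohexyl group in its place, would move the read-out beyond the scatter.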